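Thiophene Sulfonyl Variant of an Inactive Sulfonamide Series

The source may hold more compounds than are shown below. What is called first, only, known or untested is meant among the compounds shown, and "the series" means these compounds.

Compound 1 `COc1ccc(-c2cc(=O)c3c(OC)cc(OC)cc3n2Cc2ccccc2)cc1` carries a benzyl group on the aromatic nitrogen of the shared core. In a functional assay on KOPN-8 cells (Homo sapiens) for antiproliferative activity, with a stated time of 72 h (a higher number here means that more compound is needed for the effect, a lower number that less compound is needed), compound 1 gives > 17300 nM, which is a limit of the assay rather than a measured number. Compound 2 `COc1ccc(-c2cc(=O)c3c(OC)cc(OC)cc3n2S(=O)(=O)c2cccc(Br)c2)cc1` carries a (3-bromophenyl)sulfonyl group in that place instead. In this assay compound 2 gives > 58600 nM, again only a limit. Compound 3 `COc1ccc(-c2cc(=O)c3c(OC)cc(OC)cc3n2S(=O)(=O)c2ccc(C)cc2)cc1` carries a (4-methylphenyl)sulfonyl group on the same nitrogen. In this assay compound 3 gives > 44800 nM, also a limit. With every value sitting at a limit (the limit of > 17300 nM in this assay, at which 1 of the 3 values shown sits, (the limit of > 44800 nM in this assay, at which 1 of the 3 values shown sits), (the limit of > 58600 nM in this assay, at which 1 of the 3 values shown sits)), the steps a step that the two limits leave unreadable from compound 1 to compound 2, a step that the two limits leave unreadable from compound 1 to compound 3 and a step that the two limits leave unreadable from compound 2 to compound 3 cannot be read in size or direction. Compound 3 therefore stands at the limit of > 44800 nM in this assay, at which 1 of the 3 values shown sits, alongside two other compounds that are likewise known only as limits.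

Compound 4 `COc1ccc(-c2cc(=O)c3c(OC)cc(OC)cc3n2S(=O)(=O)c2ccc(Br)s2)cc1` has not yet been measured. Its difference from compound 3 is 5-bromothiophen-2-yl in place of 4-methylphenyl on a sulfonyl sulfur. No measured step bears readably on this change, and none of the three known compounds has shown a real number in this assay. Compound 4 is therefore estimated at 50000 nM, between 10000 nM and 200000 nM, most likely reported again as a limit. For compound 4 this estimate implies an expected step that the limit leaves unreadable from compound 3 to compound 4.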

Compound 4, half-maximal effective concentration: > 48200 nM
Compound 4 ended at the assay's limit (the forecaster's own chance of this, stated with the estimate: 85%); the middle value lies beyond the limit too.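

In this assay, for the compounds shown here, compound 4 is known only as a limit, as are compound 1, compound 2 and compound 3, so no step between compound 4 and any of these three can be read in size or direction: the limit of > 48200 nM in this assay, at which 1 of the 4 values shown sits. The compounds shown leave open whether any of them has a measurable half-maximal effective concentration in this assay.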